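Series notes: aryl amide variation, step to compound 4

The source may hold more compounds than are shown below. What is called first, only, known or untested is meant among the compounds shown, and "the series" means these compounds.

Compound 3, `CCOC(=O)c1ccc(NC(=O)CSC(=S)N[C@H]2CCOC2=O)cc1`, gives 60300 nM in a functional assay on MCF7 cells (Homo sapiens) for cytotoxicity, read by MTT assay, with a stated time of 72 h; a lower number here means a stronger inhibitor, a higher number a weaker inhibitor; this is the lowest of the numbers shown, with compound 1, `O=C(CSC(=S)N[C@H]1CCOC1=O)Nc1ccc(Br)cc1`, close at 66500 nM. For compound 2, `O=C(CSC(=S)N[C@H]1CCOC1=O)Nc1ccc(O)cc1`, the result in this assay is a limit of the assay, > 128000 nM (the limit of > 128000 nM in this assay, at which 1 of the 3 values shown sits). The measured steps change only the group on the aromatic carbon: a 1.1-fold lower number from compound 1 to compound 3 (0.04 log units; within the scatter), an at least 1.9-fold higher number from compound 1 to compound 2 (0.28 log units; that floor lies within the scatter), and an at least 2.1-fold lower number from compound 2 to compound 3 (0.32 log units; beyond the scatter).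

Compound 4, `O=C(CSC(=S)N[C@H]1CCOC1=O)Nc1ccc(C(=O)/C=C/c2ccccc2)cc1`, differs from compound 3 at the carbonyl carbon: 2-phenylethenyl in place of ethoxy on a carbonyl carbon. Among the measured compounds shown here, no measured step alters the carbonyl carbon's substituent, so the bearing of the measured steps is indirect. For the measured compounds named here, what they show is that exchanges of the aryl substituent moved the numbers in this assay little: the bromo to ethoxycarbonyl step stayed within the scatter, and only the step away from hydroxy reached beyond it. A step of no more than modest size is therefore expected for compound 4, with direction uncertain, and a change no larger than a 1.5-fold lower number from compound 3 to compound 4 (0.18 log units; within the scatter) is the estimate. On that basis compound 4 is estimated at 40000 nM in this assay, within a range of 10000 nM to 150000 nM.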

Compound 4, half-maximal inhibitory concentration: 44300 nM
Estimate against measurement, compound 4: 1.1-fold (0.04 log units) below; measured number inside the range.
By their numbers in this assay, from the lowest: compounds 4, 3 and 1 (each within the scatter of the next). At a limit, above all of these: compound 2.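

In this assay, among the compounds shown here, the carbonyl carbon, which no earlier step touched, takes 2-phenylethenyl in place of ethoxy with a 1.4-fold lower number from compound 3 to compound 4 (0.13 log units; within the scatter), and the full (2-phenylethenyl)carbonyl group in place of bromo on the aromatic carbon gives a 1.5-fold lower number from compound 1 to compound 4 (0.18 log units; within the scatter), so neither step can be told from the scatter. A much larger group, with one six-membered aromatic ring of carbon only and a double bond outside aromatic rings, therefore leaves compound 1, compound 3 and compound 4 at one level in this series. Only the step away from hydroxy stands out, with an at least 2.8-fold lower number from compound 2 to compound 4 (0.46 log units; beyond the scatter), and that step rests on a value that is a limit of the assay and not a number: the limit of > 128000 nM in this assay, at which 1 of the 4 values shown sits.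

The compounds shown do not separate the double bond from the added aromatic ring, since both enter together in one change. Also open, on these data alone, is whether an amine, a carboxylic acid or a longer saturated chain on the carbonyl carbon would stay at this level or produce a step beyond the scatter.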